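Removing the Difluoromethoxy Group from Compound 3

The compounds below may be only part of what the source reports. "The series", "measured", "known", "first", "only" and "open" are said of these compounds alone.

Measured compounds:
compound 1 `COCCCOc1ccnc(COc2ccc(CS(=O)(=O)c3nc4cc(OC(F)F)ccc4[nH]3)cc2OC)c1C` gives 142 nM
compound 2 `COc1cc(CS(=O)(=O)c2nc3ccccc3[nH]2)ccc1OCc1nccc(OC)c1OC` gives 212 nM
compound 3 `COc1cc(CS(=O)(=O)c2nc3cc(OC(F)F)ccc3[nH]2)ccc1OCc1nccc(OCC(F)(F)F)c1C` gives 1880 nM

In a functional assay on cells (Erythrocyte, Homo sapiens) (on this read-out higher numbers stand for weaker inhibition and lower numbers for stronger inhibition), compound 3 gives the highest of the three numbers; compound 1 and compound 2 both sit well below it. Among the measured compounds shown here, the only single-point step measured, a 13-fold higher number from compound 1 to compound 3 (1.12 log units; beyond the scatter), concerns a different change on the chain and says nothing about the group changed here. Compound 4 `COc1cc(CS(=O)(=O)c2nc3ccccc3[nH]2)ccc1OCc1nccc(OCC(F)(F)F)c1C` differs from compound 3 by hydrogen in place of difluoromethoxy on an aromatic carbon. For the measured compounds named here, compound 2 also carries a hydrogen at that position, but it differs from compound 3 in other places as well, so no measured step bears directly on this change. The expected step is therefore a 1.3-fold lower number from compound 3 to compound 4 (0.10 log units; within the scatter), that is, nothing clearly beyond the scatter. Compound 4 is estimated at 1500 nM, with a range from 600 nM to 3800 nM.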

Compound 4, half-maximal inhibitory concentration: 1310 nM
Compound 4: middle estimate off by 1.1-fold (0.06 log units), on the high side; the range from low to high includes it.
By their numbers in this assay, from the lowest: compounds 1 and 2 (each within the scatter of the next); then compounds 4 and 3 (each within the scatter of the next).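

In this assay, among the compounds shown here, putting hydrogen in place of difluoromethoxy on this aromatic carbon gives a 1.4-fold lower number from compound 3 to compound 4 (0.16 log units; within the scatter), the first direct reading of this position. On the core and chain shared by compound 3 and compound 4, the difluoromethoxy group can therefore be removed with no difference beyond the scatter. Nothing measured here gives a reason for this result.

Going by these compounds, whether the same swap would be as quiet alongside the chain of compound 1 remains open. So does the effect of an amine or a carboxylic acid on this aromatic carbon.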